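Benzyl in place of sec-butyl on an aromatic nitrogen

The source may report more compounds than this note shows. Statements on the series, on what has been measured and on what is new or still open speak of the compounds shown alone.

In an assay on HEK293 cells for activation of Kir3.1/Kir3.2 (Homo sapiens), read by thallium flux (a higher number here means a larger maximal response, a lower number a smaller maximal response), compound 1 `Cc1cc(NC(=O)Cn2nnc(-c3ccccc3)n2)n(C2CCC(F)(F)CC2)n1` gives 68%. Compound 2 `CCC(C)n1nc(C)cc1NC(=O)Cn1nnc(-c2ccccc2)n1` reaches a limit of the assay in this assay, > 69%. Among the compounds with values here, the step between them, a number at least 1 percentage points higher from compound 1 to compound 2 (that floor lies within the scatter), is the only measured step that touches this position; compound 3 `Cc1nc(-c2ccccc2)c(NC(=O)Cn2nnc(-c3ccccc3)n2)s1`, built on a different core, is "not active" (no number reported). Compound 2 stands in the same region as compound 1 on the numbers shown, and its entry is a limit (the limit of > 69% in this assay, at which 1 of the 3 values shown sits), so its true maximal response is not pinned down. Compound 4 `Cc1cc(NC(=O)Cn2nnc(-c3ccccc3)n2)n(Cc2ccccc2)n1` differs from compound 2 only by benzyl in place of sec-butyl on an aromatic nitrogen. Within the data shown here, no measured step exchanges an alkyl group for a benzyl group here, so the direction is open. Compound 4 is expected to give about 60% in this assay, between 30% and 85%. The estimated step of a number at least 9 percentage points lower from compound 2 to compound 4 (that floor lies within the scatter) is expected to be a modest fall, close to the scatter.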

Compound 4, largest response reached (Emax), in percent of the reference or control that the assay uses: 74%
Compound 4: middle estimate off by 14 percentage points, on the low side; the measured number falls inside the stated range.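

A benzyl group, with its six-membered aromatic ring, is accepted on this aromatic nitrogen in this assay: exchanging 4,4-difluorocyclohexyl for benzyl gives a number 6 percentage points higher from compound 1 to compound 4 (within the scatter). So a maximal response of this size does not require a group without an aromatic ring at this position. The step from compound 2 to compound 4 cannot be read because the entry for compound 2 is a limit: the limit of > 69% in this assay, at which 1 of the 4 values shown sits.

On these data alone, whether an aminoethyl chain or a carboxylic acid on this nitrogen would keep the response remains open. So does the effect of a methoxy group added to the benzyl.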